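Sulfur-to-selenium exchange across two cores: cytotoxicity notes

The compounds below may be only part of what the source reports. "The series", "measured", "known", "first", "only" and "open" are said of these compounds alone.

Measured so far:
compound 1 `C[Se]/C(=N\C(=O)c1cccs1)NC(=O)c1cccs1`: in a functional assay on K562 cells (Homo sapiens) for cytotoxicity, read by MTT assay, with a stated time of 72 h (a lower number here means that less compound is tolerated, a higher number that more compound is tolerated), compound 1 gives > 100000 nM, which is a limit of the assay and not a number.
compound 2 `CS/C(=N\C(=O)c1cccs1)NC(=O)c1cccs1`: in this assay compound 2 gives > 100000 nM, again only a limit.
compound 3 `CS/C(=N\C(=O)c1cc(-c2ccccc2)nc2ccccc12)NC(=O)c1cc(-c2ccccc2)nc2ccccc12`: in this assay compound 3 gives > 100000 nM, again only a limit.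

The change from compound 2 to compound 1 is a group of 2 heavy atoms (1 carbon, 1 selenium; no ring) in place of a group of 2 heavy atoms (1 carbon, 1 sulfur; no ring), on a carbon with a double bond to nitrogen. The step it made, a step that the two limits leave unreadable from compound 2 to compound 1, cannot be read because of the limit of > 100000 nM in this assay, at which 3 of the 3 values shown sit. The difference between the core of compound 2 and the core of compound 3 is not broken down here. Compound 4 `C[Se]/C(=N\C(=O)c1cc(-c2ccccc2)nc2ccccc12)NC(=O)c1cc(-c2ccccc2)nc2ccccc12` has not been measured; it carries the same change relative to compound 3, namely (a group of 2 heavy atoms (1 carbon, 1 selenium; no ring) in place of a group of 2 heavy atoms (1 carbon, 1 sulfur; no ring), on a carbon with a double bond to nitrogen). No readable counterpart exists for this change, so the expectation rests only on the limit at which compound 3 sits. The expected step that the limit leaves unreadable from compound 3 to compound 4 is therefore taken as essentially none, with the measurement most likely returning a limit once more. Compound 4 is expected to give about 150000 nM in this assay, with a range from 40000 nM to 600000 nM.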

Compound 4, concentration lethal to 50% of the cells: 73100 nM
Estimate against measurement, compound 4: 2.1-fold (0.31 log units) above; low and high end bracket the measured number.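

On the second core, the selenium-for-sulfur change gives, in this assay, an at least 1.3-fold lower number from compound 3 to compound 4 (0.13 log units; that floor lies within the scatter). Going by these compounds, the true size of this step remains unknown, and it may be larger than this floor, because one end of the step is not a number: the limit of > 100000 nM in this assay, at which 3 of the 4 values shown sit. The step from compound 2 to compound 1 cannot be read, as both values are limits, so nothing here shows that the change carries from one core to the other.

Open, on these data alone, is whether a longer chain in place of the methyl of the group that enters, or an amine or a carboxylic acid on either core, would give a readable number in this assay. Also open is what each core contributes by itself, which no pair of compounds shown isolates.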